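From hydroxycyclohexyl to carbamoylcyclobutyl at the lowest value

The source may report more compounds than this note shows. Statements on the series, on what has been measured and on what is new or still open speak of the compounds shown alone.

Results so far in an ADME assay on S9 fraction from liver (Homo sapiens) for metabolic stability, with a stated time of 1 h; a higher number here means that more of the compound is left, a lower number that less of the compound is left
compound 1 `N#Cc1cnc(NCc2cnccc2C(F)(F)F)cc1NC[C@H]1C[C@H](O)C1` gives 93%
compound 2 `N#Cc1cnc(NCc2ccccc2C(F)(F)F)cc1N[C@H]1CC[C@@H](O)CC1` gives 0%
compound 3 `N#Cc1cnc(NCc2cnccc2C(F)(F)F)cc1NC1CCOCC1` gives 91%

Compound 2 stands lowest of the three, well beyond the scatter from both others. Compound 4 `N#Cc1cnc(NCc2ccccc2C(F)(F)F)cc1N[C@H]1C[C@H](C(N)=O)C1` differs from it in one place, on a nitrogen on an aromatic ring, by 3-carbamoylcyclobutyl in place of 4-hydroxycyclohexyl on a nitrogen on an aromatic ring (a four-membered ring replaces a six-membered one). Within the data shown here, one measured step bears on this place, a number 2 percentage points lower from compound 1 to compound 3 (within the scatter), but it begins from a high number, so it is a weak guide here. Compound 2 at 0% has no room to fall, so only a rise or no change can be expected. The expected move is a number 25 percentage points higher from compound 2 to compound 4 (beyond the scatter) in this assay as a rough estimate. Compound 4 is expected at 25% (estimated range 3% to 65%).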

Compound 4, percent of the compound remaining: 68%
For compound 4 the middle estimate is 43 percentage points below the measured one; the measured number lies above the stated range.
By their numbers in this assay, from the lowest: compound 2; then compound 4; then compounds 3 and 1 (each within the scatter of the next).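

Swapping 4-hydroxycyclohexyl for 3-carbamoylcyclobutyl on a nitrogen on an aromatic ring gives a number 68 percentage points higher from compound 2 to compound 4 (beyond the scatter) in this assay, so this place can carry a very large change, which the earlier step there, a number 2 percentage points lower from compound 1 to compound 3 (within the scatter), did not show. Ring size and the group on the ring change together in this step, so it cannot credit either alone. Nothing available explains the rise. Open, as far as these compounds go, is how a cyclohexyl ring carrying the carbamoyl group compares, which would separate the two changes. Also open, from the compounds shown here alone, is how a carboxylic acid on the cyclobutyl ring behaves.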